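This account rests on a few compounds, and the source may have more. Where it says the series, first, only, none or still open, it means among the compounds named here.

Measured so far: compound 1 `Cc1ccc(-c2nc3sc(Cc4ccc(Cl)cc4)nn3c2Br)cc1`, compound 2 `O=Cc1c(-c2ccc(Cl)cc2)nc2sc(Cc3ccc(Cl)cc3)nn12`, compound 3 `N#CSc1c(-c2ccc(Cl)cc2)nc2sc(Cc3ccc(Cl)cc3)nn12`.

In a functional assay on HeLa cells (Homo sapiens) for cytotoxicity, with a stated time of 72 h (on this read-out higher numbers stand for weaker inhibition and lower numbers for stronger inhibition), compound 2 gives 16000 nM. Compound 3 gives 20000 nM; of the two numbers it is the upper one, yet the step of a 1.3-fold higher number from compound 2 to compound 3 (0.10 log units; within the scatter) marks no real difference. Compound 1 gives only a limit of the assay, > 250000 nM (the limit of > 250000 nM in this assay, at which 1 of the 3 values shown sits).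

Compound 4 `Cc1ccc(-c2nc3sc(Cc4ccc(Cl)cc4)nn3c2SC#N)cc1` differs from compound 3 by methyl in place of chloro on an aromatic carbon. Going by the values given here, no measured step touches this position; the only measured step, a 1.3-fold higher number from compound 2 to compound 3 (0.10 log units; within the scatter), concerns the substituent on the core. Compound 1 carries the same 4-methylphenyl and shows only a limit, so a higher number is expected for compound 4, with a fair chance of a limit again. The expected step is a 3.0-fold higher number from compound 3 to compound 4 (0.48 log units; beyond the scatter). Compound 4 is estimated at 60000 nM, range 15000 nM to 250000 nM.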

Compound 4, half-maximal inhibitory concentration: 22000 nM
Compound 4: the middle estimate sits 2.7-fold (0.44 log units) above what was measured; the range from low to high includes it.
By their numbers in this assay, from the lowest: compounds 2, 3 and 4 (each within the scatter of the next). At a limit, above all of these: compound 1.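

In this assay, 4-chlorophenyl to 4-methylphenyl changes nothing that can be told from the scatter: a 1.1-fold higher number from compound 3 to compound 4 (0.04 log units; within the scatter). The 4-methylphenyl group therefore does not tie to a limit, since compound 4 carries it and gives a number. With that group held, the gap lies at the substituent on the core, with cyanosulfanyl in place of bromo: an at least 11-fold lower number from compound 1 to compound 4 (1.05 log units; beyond the scatter), a step read from a limit of the assay.

Open, from the compounds shown here alone, is how an amine or a carboxylic acid would read at that core substituent. Also open, going by these compounds, is whether a longer chain in place of methyl would leave the number as flat.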